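Cyclopentyl to cyclohexyl on a cathepsin S inhibitor

The source may report more compounds than this note shows. Statements on the series, on what has been measured and on what is new or still open speak of the compounds shown alone.

Of the compounds shown here, three share a core and have been tested in an assay on isolated protein for inhibition of cathepsin S (Homo sapiens); on this read-out lower numbers stand for stronger inhibition and higher numbers for weaker inhibition. Compound 1 `O=C(N[C@@H](CCc1ccccc1)CNc1ccc(OC(F)(F)F)cc1)[C@@H](CC(=O)N1CCOCC1)CC1CCCCC1` gives 18 nM in this assay. Compound 2 `CC(C)[C@@H](CNc1ccc(OC(F)(F)F)cc1)NC(=O)[C@H](CCCc1ccccc1)CC(=O)N1CCOCC1` gives 14 nM. Compound 3 `CC(C)[C@@H](CNc1ccc(OC(F)(F)F)cc1)NC(=O)[C@@H](CC(=O)N1CCOCC1)CC1CCCC1` gives 38 nM, the highest of the three numbers; its nearest neighbour is compound 1 and its furthest is compound 2, both beyond the scatter.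

Compound 4 `CC(C)[C@@H](CNc1ccc(OC(F)(F)F)cc1)NC(=O)[C@@H](CC(=O)N1CCOCC1)CC1CCCCC1` has not yet been measured. It differs from compound 3 in one place: cyclohexyl in place of cyclopentyl on a saturated chain carbon, two bonds along the chain from a carbonyl carbon. The same difference, cut one bond further out, reads cyclopentylmethyl to cyclohexylmethyl.

Among the compounds with values here, only one measured step touches this position. a 2.7-fold higher number from compound 2 to compound 3 (0.43 log units; beyond the scatter) shows that replacing phenethyl with cyclopentyl at this position raised the number modestly. Within the data shown here, the numbers of compound 1, which carries cyclohexyl at the same place but differs elsewhere, and compound 3 suggest that a six-membered ring here is compatible with a lower number, though no single-change step links those two. The expected step from compound 3 to compound 4 is therefore a 1.7-fold lower number from compound 3 to compound 4 (0.24 log units; within the scatter), a modest decrease that may barely clear the scatter. Compound 4 is expected to give about 22 nM, within a range from 10 nM to 50 nM.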

Compound 4, inhibition constant: 11 nM
Compound 4: the middle estimate sits 2.0-fold (0.30 log units) above what was measured, and the stated range covers the measured number.
By their numbers in this assay, from the lowest: compounds 4, 2 and 1 (each within the scatter of the next); then compound 3.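

In this assay, one extra ring carbon at this position, cyclohexyl in place of cyclopentyl, gives a 3.5-fold lower number from compound 3 to compound 4 (0.54 log units; beyond the scatter) and so moves the number beyond the scatter, even though neither ring carries any hydrogen-bond donors or acceptors. Cyclohexyl and phenethyl at this same place cannot be told apart, since a 1.3-fold lower number from compound 2 to compound 4 (0.10 log units; within the scatter) stays within the scatter, which leaves cyclopentyl as the only one of the three groups here with a clearly higher number. With cyclohexyl held in place, the other site, on a saturated chain carbon bound to an amide-type nitrogen and a saturated chain carbon, also shows no clear difference: isopropyl in place of phenethyl gives a 1.6-fold lower number from compound 1 to compound 4 (0.21 log units; within the scatter) and this too stays within the scatter.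

Nothing available here accounts for why the six-membered ring gives the lower number. From the compounds shown here alone, it also remains open whether a still larger ring such as cycloheptyl, an open chain such as isobutyl, or a cyclohexyl ring carrying an amine would hold the number at this position.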